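Pyridine nitrile series: fluoroalkyl swap on the diazine ring

The compounds below may be only part of what the source reports. "The series", "measured", "known", "first", "only" and "open" are said of these compounds alone.

Measured compounds in an assay on isolated protein for inhibition of protein kinase C delta type (Homo sapiens), read by TR-FRET, with a stated time of 2 h; on this read-out lower numbers stand for stronger inhibition and higher numbers for weaker inhibition:
Compound 1 `CO[C@H]1CC[C@@H](Nc2cc(NCc3cnccc3C(F)(F)F)ncc2C#N)CC1` gives 5000 nM.
Compound 2 `N#Cc1cnc(NCc2ccccc2C(F)(F)F)cc1N[C@H]1C[C@@H](C(N)=O)C1` gives 4200 nM.
Compound 3 `N#Cc1cnc(NCc2cncnc2C(F)(F)F)cc1N[C@H]1CC[C@@H](O)CC1` gives 450 nM.

Compound 3 carries the lowest number of the three; its gaps to compound 2 and to compound 1 are both beyond the usual scatter, so within this small set it is the most potent, and nothing in the shown values goes against that. The three differ at several places at once, so no single change can be read from their values.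

Compound 4 `CC(C)(F)c1ncncc1CNc1cc(N[C@H]2CC[C@@H](O)CC2)c(C#N)cn1` keeps the whole of compound 3 except for one group: 1-fluoro-1-methylethyl in place of trifluoromethyl on an aromatic carbon. Within the data shown here, no measured pair in the set isolates this kind of exchange, so there is no precedent to lean on. Both groups are of the same heavy-atom count and neither carries donors or acceptors, so a large step is not expected; a modest weakening, possibly within the scatter, is the working assumption. Compound 4 is expected to give about 650 nM, with a plausible range from 220 nM to 2000 nM. The estimated step of a 1.4-fold higher number from compound 3 to compound 4 (0.16 log units; within the scatter) is small and should be regarded as uncertain until measured.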

Compound 4, half-maximal inhibitory concentration: 32 nM
The estimate for compound 4 lay 20-fold (1.31 log units) above the measured number; measured number outside the range, below it.
By their numbers in this assay, from the lowest: compound 4; then compound 3; then compounds 2 and 1 (each within the scatter of the next).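

In this assay, the group on this aromatic carbon, next to the ring nitrogen and ortho to a large group, has a strong effect on the number: 1-fluoro-1-methylethyl in place of trifluoromethyl gives a 14-fold lower number from compound 3 to compound 4 (1.15 log units; beyond the scatter), with the rest of the structure unchanged. The size of the step was not foreseeable from the simple counts, since both groups have 4 heavy atoms, 0 hydrogen-bond donors and 0 hydrogen-bond acceptors, and they differ in their split of carbon and fluorine. Nothing available gives a reason for this step.

Going by these compounds, it remains open whether the single fluorine in 1-fluoro-1-methylethyl is needed for the lower number, which isopropyl or tert-butyl at the same place would test, and whether a cyclopropyl group would serve as well. On these data alone, it also remains open whether the same exchange would give a step of similar size with the methoxy-bearing group of compound 1 or the carboxamide-bearing group of compound 2 in place of the hydroxyl-bearing group of compound 4.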